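A few compounds are considered here, and "the series" means these few. Any claim that something is new, unique, unknown or untested is made for them only; others in the source may bear on it.

Among the measured compounds shown here, in a functional assay on a cell-free system (Platelet, plasma, Homo sapiens) for inhibition (on this read-out higher numbers stand for weaker inhibition and lower numbers for stronger inhibition), compound 2 (`COc1cc(OC)cc(C(=O)N(CCN2CCC(OCC(=O)O)CC2)c2ccc(C)cc2)c1`) gives 530 nM, the higher of the two numbers so far, while compound 1 (`Cc1ccc(N(CCN2CCC(OCC(=O)O)CC2)C(=O)c2cccc(C)c2)cc1`) gives 160 nM. Compound 3 (`COc1cccc(C(=O)N(CCN2CCC(OCC(=O)O)CC2)c2ccc(C)cc2)c1OC`) carries 2,3-dimethoxyphenyl in place of 3,5-dimethoxyphenyl on a carbonyl carbon. For the measured compounds named here, the only measured step at this carbonyl carbon, a 3.3-fold higher number from compound 1 to compound 2 (0.52 log units; beyond the scatter), is modest and offers loose guidance, since it starts from a different group. No change beyond the scatter is therefore expected, and no direction is firmly indicated. The estimated step is a 1.3-fold lower number from compound 2 to compound 3 (0.12 log units; within the scatter). For compound 3 the expected value is 400 nM, with an estimated range of 130 nM to 1200 nM.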

Compound 3, half-maximal inhibitory concentration: 1600 nM
Beside the measured number, compound 3's estimate is 4.0-fold (0.60 log units) below it, and the stated range ends below it.
By their numbers in this assay, from the lowest: compound 1; then compound 2; then compound 3.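

In this assay, the same atoms arranged differently on the carbonyl carbon are enough to move the number: 2,3-dimethoxyphenyl in place of 3,5-dimethoxyphenyl gives a 3.0-fold higher number from compound 2 to compound 3 (0.48 log units; beyond the scatter), so this position responds to the arrangement of the two methoxy groups and not only to their presence. Measured against 3-methylphenyl, the same group gives a 10-fold higher number from compound 1 to compound 3 (1.00 log units; beyond the scatter), the widest step among these three compounds. Nothing available explains why the arrangement matters.

From the compounds shown here alone, how a plain phenyl, a phenyl bearing a single methoxy group or a pyridine would read at this carbonyl carbon remains open.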